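The compounds below may be only part of what the source reports. "The series", "measured", "known", "first", "only" and "open" are said of these compounds alone.

Compound 1 `O=c1cc(Cn2cc(C3CC3)nn2)c2ccc(O)cc2o1` and compound 2 `CC(O)c1cn(Cc2cc(=O)oc3cc(O)ccc23)nn1` share one core and differ only in the group carried on the five-membered aromatic ring. In a functional assay on A549 cells (Homo sapiens) for inhibition, read by MTT assay, with a stated time of 72 h (on this read-out higher numbers stand for weaker inhibition and lower numbers for stronger inhibition), compound 1 gives 91700 nM. Compound 2 reaches only a limit of the assay, > 100000 nM, so no number is known for it. The step of an at least 1.0-fold higher number from compound 1 to compound 2 (0.03 log units; that floor lies within the scatter) is thus a floor and tells little, as the limit of > 100000 nM in this assay, at which 1 of the 2 values shown sits, shows. Compound 3 `O=c1cc(Cn2cc(CCCO)nn2)c2ccc(O)cc2o1` has not yet been measured. Its change from compound 2 is 3-hydroxypropyl in place of 1-hydroxyethyl on an aromatic carbon. Within the data shown here, only one measured step bears on this place, the one from compound 1 to compound 2, which exchanged one small group for another without any movement beyond the scatter; the change to compound 3 exchanges one hydroxyalkyl chain for a longer one at the same place. With both measured neighbours weak, compound 3 is expected to remain weak in this assay, and the expected step is a number no higher from compound 2 to compound 3 (the limit leaves the size open), nothing beyond the scatter. Compound 3 is therefore estimated at about 100000 nM, between 55000 nM and 200000 nM, and a further limit rather than a number is considered likely.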

Compound 3, half-maximal inhibitory concentration: 96200 nM
Beside the measured number, compound 3's estimate is 1.0-fold (0.02 log units) above it; the range from low to high includes it.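

Compound 3 gives this position its first comparison between two real numbers: in this assay the exchange of cyclopropyl for 3-hydroxypropyl is a 1.0-fold higher number from compound 1 to compound 3 (0.02 log units; within the scatter). An open hydroxyalkyl chain on this aromatic carbon therefore reads the same as the small ring within the scatter, so the ring itself is not needed to hold the number where it stands. The other comparison is weaker, since compound 2 has only a limit of the assay and the step of an at least 1.0-fold lower number from compound 2 to compound 3 (0.01 log units; that floor lies within the scatter) is a floor that says little about the chain length: the limit of > 100000 nM in this assay, at which 1 of the 3 values shown sits.

The compounds shown leave open whether any group on this aromatic carbon can move the number beyond the scatter in this assay, since a hydroxyalkyl chain and a cyclopropyl ring are all that is seen here. Going by these compounds, how a plain propyl chain would compare with 3-hydroxypropyl, and how an amine, a carboxylic acid or a phenyl ring would read at the same place, also remains unknown.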